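Swapping a Carbamate for a Fluoropyrimidine on the Piperazine

This account rests on a few compounds, and the source may have more. Where it says the series, first, only, none or still open, it means among the compounds named here.

Compound 1 `C[C@@H]1CN(C(=O)OC(C)(C)C)CCN1c1ncc(OCC2CCN(S(C)(=O)=O)CC2)cn1`: 29 nM
Compound 2 `Cc1cnccc1COc1cnc(N2CCN(C(=O)OC(C)(C)C)C[C@H]2C)nc1`: 184 nM
Compound 3 `CC(C)OC(=O)N1CCN(c2ncc(OCc3ccncc3C#N)cn2)[C@H](C)C1`: 112 nM

All three numbers come from an in vitro functional assay on HEK293S cells for agonist activity at Glucose-dependent insulinotropic receptor (Homo sapiens), read by HTRF and cAMP accumulation, with a stated time of 45 min; a lower number here means that less compound is needed, a higher number that more compound is needed for the effect. Compound 3 gives the second highest number of the three; its gap to compound 2 lies within the scatter, while its gap to compound 1 lies beyond it. Going by the values given here, the only measured step, a 6.3-fold higher number from compound 1 to compound 2 (0.80 log units; beyond the scatter), concerns the group on the ether side of the shared core. Compound 4 `C[C@@H]1CN(c2ncc(F)cn2)CCN1c1ncc(OCc2ccncc2C#N)cn1` is changed elsewhere: 5-fluoropyrimidin-2-yl in place of isopropoxycarbonyl on an amine nitrogen in a ring. Among the compounds with values here, no measured step touches this ring nitrogen, so the data give no direction for the change; the expectation is a step within the scatter. The expected step is a 1.2-fold lower number from compound 3 to compound 4 (0.09 log units; within the scatter). Compound 4 is thus estimated at 90 nM, within a range of 25 nM to 300 nM.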

Compound 4, half-maximal effective concentration: 63 nM
The estimate for compound 4 lay 1.4-fold (0.15 log units) above the measured number; low and high end bracket the measured number.
By their numbers in this assay, from the lowest: compound 1; then compounds 4, 3 and 2 (each within the scatter of the next, the first and the last beyond it).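

Going by these compounds alone, this is the first measured step on this amine nitrogen in a ring: a 1.8-fold lower number from compound 3 to compound 4 (0.25 log units; within the scatter). An aromatic ring with two ring nitrogens and a fluorine can therefore take the place of isopropoxycarbonyl in this pair without a change that can be told from the scatter. No measurement here gives a reason for this outcome.

As far as these compounds go, whether the swap would give the same result in compound 1, which carries 1-(methylsulfonyl)piperidin-4-yl, remains open. So does the part played by the fluorine, since a plain pyrimidin-2-yl or a 5-chloropyrimidin-2-yl group on this nitrogen lies outside the compounds shown.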